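The source may hold more compounds than are shown below. What is called first, only, known or untested is meant among the compounds shown, and "the series" means these compounds.

Measured compounds:
Compound 1, `O/N=C(/Nc1cccc(F)c1)c1ccc2occc2c1`, with 20000 nM in an assay on tissue (HeLa cells) for inhibition of Indoleamine 2,3-dioxygenase 1 (Homo sapiens), read by spectrophotometry; on this read-out lower numbers stand for stronger inhibition and higher numbers for weaker inhibition.
Compound 2, `COCc1cc2cc(/C(=N\O)Nc3cccc(F)c3)ccc2o1`, with 6100 nM.
Compound 3, `COCc1cc2cc(/C(=N\O)Nc3cccc(Cl)c3)ccc2o1`, with 2200 nM.

Among these three numbers compound 2 stands second highest. Its nearest neighbour is compound 3, reached by a 2.8-fold lower number from compound 2 to compound 3 (0.44 log units; beyond the scatter); compound 1 lies furthest off, and the step of a 3.3-fold lower number from compound 1 to compound 2 (0.52 log units; beyond the scatter) runs in the lowering direction as well.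

Compound 4, `O/N=C(/Nc1cccc(F)c1)c1ccc2oc(-c3ccccc3)cc2c1`, is not yet measured. From compound 2 it differs in one place: phenyl in place of methoxymethyl on an aromatic carbon.

Of the two measured steps only one bears on this position. The change from compound 1 to compound 2 introduced the methoxymethyl at that carbon of the shared core, and a 3.3-fold lower number from compound 1 to compound 2 (0.52 log units; beyond the scatter) shows a modest gain. The change from compound 2 to compound 3 concerns chloro in place of fluoro and says nothing about the carbon in question. Within the data shown here, there is no measured example of a phenyl at that carbon, so the size of the step is uncertain; since a group there was better than hydrogen in a 3.3-fold lower number from compound 1 to compound 2 (0.52 log units; beyond the scatter), a modest move, most likely a small lowering, is expected rather than a large one. The estimate for compound 4 is therefore 4000 nM, within 1000 nM to 16000 nM, meaning an expected step of a 1.5-fold lower number from compound 2 to compound 4 (0.18 log units; within the scatter).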

Compound 4, half-maximal inhibitory concentration: 10600 nM
The estimate for compound 4 lay 2.7-fold (0.42 log units) below the measured number; the measured number falls inside the stated range.
By their numbers in this assay, from the lowest: compound 3; then compounds 2, 4 and 1 (each within the scatter of the next, the first and the last beyond it).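

At the carbon next to the ring oxygen, this assay records a 1.7-fold higher number from compound 2 to compound 4 (0.24 log units; within the scatter) when phenyl, a six-membered aromatic ring of carbon only, replaces methoxymethyl. Compared with hydrogen at that carbon, phenyl gives a 1.9-fold lower number from compound 1 to compound 4 (0.28 log units; within the scatter) and so cannot be told apart from either hydrogen or methoxymethyl, whereas methoxymethyl stood apart from hydrogen with a 3.3-fold lower number from compound 1 to compound 2 (0.52 log units; beyond the scatter) on the same read-out. Nothing shown here accounts for either step, so the result remains a description of the numbers alone.

The compounds leave open whether the step seen with methoxymethyl depends on its oxygen or on its chain, which a hydroxymethyl, an ethyl or an aminomethyl group at this carbon would help to separate. They also leave open whether phenyl at this carbon would behave in the same way with chloro in place of fluoro, the change that separates compound 3 from compound 2.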